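The source may hold more compounds than are shown below. What is called first, only, known or untested is meant among the compounds shown, and "the series" means these compounds.

Measured compounds: compound 1 `[O-][n+]1nc(NCCO)[n+]([O-])c2ccccc21` gives 22400 nM; compound 2 `COc1ccc(Nc2n[n+]([O-])c3ccccc3[n+]2[O-])cc1` gives 12000 nM; compound 3 `Cc1ccc(Nc2n[n+]([O-])c3ccccc3[n+]2[O-])cc1` gives 10300 nM.

All three were tested in a functional assay on PC-3 cells (Homo sapiens) for cytotoxicity, read by MTT assay, with a stated time of 48 h; a higher number here means a weaker inhibitor, a lower number a stronger inhibitor. Among them, compound 1 stands at the top of the three numbers, but its gap to compound 2 lies within the scatter, so the two cannot be told apart; only the gap to compound 3 is beyond the scatter. Among the measured compounds shown here, the one step that joins two measured compounds, from compound 2 to compound 3, is a 1.2-fold lower number from compound 2 to compound 3 (0.07 log units; within the scatter), and it concerns a substituent on an aromatic carbon, not the chain on the amino nitrogen.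

Compound 4 `C=CCNc1n[n+]([O-])c2ccccc2[n+]1[O-]` is not yet measured. It differs from compound 1 in that (vinyl in place of hydroxymethyl on a saturated chain carbon bound to a nitrogen on an aromatic ring). For the measured compounds named here, no measured pair shows this kind of change, so nothing in the data fixes its size or direction. Going by the values given here, the one known step, on a different part of the molecule, stayed within the scatter, and in the absence of any step on the chain it is expected that the change to compound 4 will also produce no step beyond the scatter in this assay, a 1.4-fold lower number from compound 1 to compound 4 (0.15 log units; within the scatter). Compound 4 is therefore estimated at 16000 nM, within 5000 nM to 50000 nM.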

Compound 4, half-maximal inhibitory concentration: > 56000 nM
Compound 4: only a limit was reported (the forecaster's own chance of this, stated with the estimate: 10%); middle value at least 3.5-fold (0.54 log units) away from the limit.
By their numbers in this assay, from the lowest: compounds 3, 2 and 1 (each within the scatter of the next, the first and the last beyond it). At a limit, above all of these: compound 4.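

In this assay compound 4 is reported only as a limit, > 56000 nM. Going from (2-hydroxyethyl)amino to allylamino gives an at least 2.5-fold higher number from compound 1 to compound 4 (0.39 log units; beyond the scatter), the first single change among these compounds to go beyond the scatter, whereas the only earlier step, a 1.2-fold lower number from compound 2 to compound 3 (0.07 log units; within the scatter), concerned a substituent on an aromatic carbon and stayed within it. The change exchanges a hydroxymethyl carrying 1 hydrogen-bond donor and 1 hydrogen-bond acceptor for a vinyl carrying neither, and the full size of the resulting step remains unknown, with only a limit available for compound 4: the limit of > 56000 nM in this assay, at which 1 of the 4 values shown sits.

The compounds shown leave open whether the step follows from losing the hydroxyl or from gaining the double bond, a question that a saturated propyl chain in the same place could help to separate. They also leave open how the chain tolerates other end groups, such as an amine, a carboxylic acid or a methyl ether, and whether a longer chain bearing a terminal hydroxyl would keep the number of compound 1 or shift it.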